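Cyclohexyl for tert-Butoxymethyl at the Hydroxy Acid Side Chain

This account rests on a few compounds, and the source may have more. Where it says the series, first, only, none or still open, it means among the compounds named here.

Measured so far:
- Compound 1 `O=C(NCc1cc(Cl)ccc1-n1cnnn1)[C@@H]1[C@H]2C[C@H]2CN1C(=O)[C@H](O)Cc1ccccc1`: 96 mL.min-1.g-1
- Compound 2 `CC(C)(C)OC[C@@H](O)C(=O)N1C[C@@H]2C[C@@H]2[C@H]1C(=O)NCc1cc(Cl)ccc1-n1cnnn1`: 37 mL.min-1.g-1

In an ADME assay on liver for metabolic stability, with Liver microsome (Homo sapiens) as the target, read by LC-MS, using microsomes (on this read-out higher numbers stand for fast clearance and lower numbers for slow clearance), compound 2 gives the lowest of the two numbers, and the nearest measured neighbour, compound 1, sits higher by the step of a 2.6-fold lower number from compound 1 to compound 2 (0.41 log units; beyond the scatter) read in reverse. Compound 3 `O=C(NCc1cc(Cl)ccc1-n1cnnn1)[C@@H]1[C@H]2C[C@H]2CN1C(=O)[C@H](O)C1CCCCC1` has not yet been measured. It differs from compound 2 by cyclohexyl in place of (tert-butoxy)methyl on a saturated chain carbon bound to a carbonyl carbon and an oxygen on a saturated carbon. Going by the values given here, the only measured step that bears on this change is a 2.6-fold lower number from compound 1 to compound 2 (0.41 log units; beyond the scatter), in which a hydrocarbon group gave way to one carrying an ether oxygen and the clearance number fell. The change to compound 3 removes that ether oxygen and puts in an all-carbon ring, so the step is expected to go the other way, and compound 3 is expected to show a 2.4-fold higher number from compound 2 to compound 3 (0.39 log units; beyond the scatter) in this assay. The estimate for compound 3 is therefore 90 mL.min-1.g-1, within the range 45 mL.min-1.g-1 to 180 mL.min-1.g-1.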

Compound 3, intrinsic clearance in microsomes: 110 mL.min-1.g-1
Compound 3: the middle estimate sits 1.2-fold (0.09 log units) below what was measured; the range from low to high includes it.
By their numbers in this assay, from the lowest: compound 2; then compounds 1 and 3 (each within the scatter of the next).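

In this assay the swap of (tert-butoxy)methyl for cyclohexyl at this saturated chain carbon gives a 3.0-fold higher number from compound 2 to compound 3 (0.47 log units; beyond the scatter), so a second all-carbon group now stands apart from compound 2. Benzyl and cyclohexyl do not separate at this place, as a 1.1-fold higher number from compound 1 to compound 3 (0.06 log units; within the scatter) shows, so among these three compounds only the group carrying an ether oxygen stands apart, and an aromatic ring is not needed to reach the number of compound 1. Nothing measured here gives a cause for these differences.

The compounds shown leave open whether the ether oxygen or the rest of the (tert-butoxy)methyl group goes with the lower number of compound 2. A tetrahydropyranyl ring, which puts an oxygen into the six-membered ring, or a methoxymethyl chain would bear on that question.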